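Thiophene acyl exchange from the limit-bound compound 2

This account rests on a few compounds, and the source may have more. Where it says the series, first, only, none or still open, it means among the compounds named here.

In a functional assay on RPMI-8226 cells (Homo sapiens) for cytotoxicity, read by fluorescence, with a stated time of 72 h (on this read-out lower numbers stand for stronger inhibition and higher numbers for weaker inhibition), compound 2 (`CCOC(=O)n1nc(N)c(/N=N/c2ccc(O)cc2)c1N`) gives > 100000 nM as a limit and not a number. Compound 1 (`Nc1nn(C(=O)c2ccc([N+](=O)[O-])cc2)c(N)c1/N=N/c1ccc(O)cc1`) gives > 100000 nM as a limit too. Among the measured compounds shown here, the only measured exchange on this carbonyl carbon is a step that the two limits leave unreadable from compound 1 to compound 2 with no size to carry forward. Compound 3 (`Cn1nc(N)c(/N=N/c2ccncc2)c1N`) gives 50000 nM but differs in more than one place. Compound 4 (`Nc1nn(C(=O)c2cccs2)c(N)c1/N=N/c1ccc(O)cc1`) has thiophen-2-yl in place of ethoxy on a carbonyl carbon. Compound 1 and compound 2 both stand at the limit of > 100000 nM in this assay, at which 2 of the 3 values shown sit, so no clear gain is expected in this assay from this exchange. The expected step is an at least 1.2-fold lower number from compound 2 to compound 4 (0.09 log units; that floor lies within the scatter) and no direction is firmly expected. For compound 4 the estimate is 80000 nM with an expected range of 20000 nM to 200000 nM in this assay.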

Compound 4, half-maximal inhibitory concentration: > 100000 nM
Compound 4 ended at the assay's limit; the forecaster's own chance of this, stated with the estimate: 60%; middle value at least 1.2-fold (0.09 log units) from the limit.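

Among the compounds shown here, no step among compound 1, compound 2 and compound 4 can be read, as all three give only a limit and not a number: the limit of > 100000 nM in this assay, at which 3 of the 4 values shown sit. On these data alone, whether any group on this carbonyl carbon gives a readable value in this assay stays open.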